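This account rests on a few compounds, and the source may have more. Where it says the series, first, only, none or still open, it means among the compounds named here.

Measured compounds:
Compound 1 `COC(=O)c1cc(=O)c2c(OC)cc(OC)cc2n1S(=O)(=O)c1ccc(C)cc1`: 9700 nM
Compound 2 `COc1ccc(-c2cc(=O)c3c(OC)cc(OC)cc3n2S(=O)(=O)c2ccc(C=O)cc2)cc1`: > 34400 nM
Compound 3 `COc1ccc(-c2cc(=O)c3c(OC)cc(OC)cc3n2S(=O)(=O)c2c(F)c(F)c(F)c(F)c2F)cc1`: 4100 nM

Going by these compounds, in a functional assay on SUP-B15 cells (Homo sapiens) for antiproliferative activity, with a stated time of 72 h (on this read-out higher numbers stand for an effect only at larger amounts of compound and lower numbers for an effect already at smaller amounts), compound 2 gives only a limit, > 34400 nM, so its true number is unknown; (the limit of > 34400 nM in this assay, at which 1 of the 3 values shown sits). Compound 4 `COc1ccc(-c2cc(=O)c3c(OC)cc(OC)cc3n2S(=O)(=O)c2ccc(Br)s2)cc1` differs from compound 2 in one place: 5-bromothiophen-2-yl in place of 4-formylphenyl on a sulfonyl sulfur. Among the measured compounds shown here, the only measured step at this place is an at least 8.3-fold lower number from compound 2 to compound 3 (0.92 log units; beyond the scatter), which replaced the same group by a pentafluorophenyl and gave a real number. A 5-bromothiophen-2-yl has not been measured here, so the size of its step rests on that single comparison. Compound 4 is therefore expected to show a lower number, by about an at least 3.8-fold lower number from compound 2 to compound 4 (0.58 log units; beyond the scatter), still a modest change. In this assay compound 4 is estimated at 9000 nM, with a range from 2500 nM to 34400 nM.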

Compound 4, half-maximal effective concentration: > 48200 nM
Compound 4: only a limit was reported (the forecaster's own chance of this, stated with the estimate: 30%); at least 5.3-fold (0.72 log units) between middle value and limit.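

At this place on the sulfonyl sulfur, the gain seen with the pentafluorophenyl does not carry over to the 5-bromothiophen-2-yl: in this assay there is an at least 11-fold higher number from compound 3 to compound 4 (1.07 log units; beyond the scatter). Compound 4 gives only a limit, > 48200 nM. The step from the 4-formylphenyl cannot be read, since both ends are limits, so replacing that group does not by itself give a measurable number here. Going by these compounds, whether the result of compound 3 depends on its fluorines or on its six-membered ring remains open. On these data alone, what an amine on a phenyl at this sulfonyl sulfur would give also remains open.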